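Isopropoxy to cyclobutyloxy: expected clearance of compound 3

The source may report more compounds than this note shows. Statements on the series, on what has been measured and on what is new or still open speak of the compounds shown alone.

Measured so far in an ADME assay on the whole organism (Mus musculus, strain CD-1) for pharmacokinetics; a lower number here means slower removal, a higher number faster removal of the compound
Compound 1 `COc1cc([C@](O)(CCN(C)C)[C@@H](c2cc3cc(Br)ccc3nc2OC)c2cccc(OC)c2F)cc(OC(C)C)n1` at 8.9 mL/min/kg
Compound 2 `COc1cc([C@](O)(CCN(C)C)[C@@H](c2cc3cc(Br)ccc3nc2OC)c2ccnc(OC)c2OC)cc(OC(C)C)n1` at 6.8 mL/min/kg

Compound 2 at 6.8 mL/min/kg lies within the scatter of compound 1 at 8.9 mL/min/kg in this assay and so holds no distinct place on these numbers. Compound 3 `COc1cc([C@](O)(CCN(C)C)[C@@H](c2cc3cc(Br)ccc3nc2OC)c2ccnc(OC)c2OC)cc(OC2CCC2)n1` differs from compound 2 at one place, isopropoxy to cyclobutyloxy, as follows: cyclobutyl in place of isopropyl on an oxygen on an aromatic ring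

Going by the values given here, the one measured step is a 1.3-fold lower number from compound 1 to compound 2 (0.12 log units; within the scatter) and it leaves the isopropyl group untouched. Among the compounds with values here, no measured step changes the group on that oxygen, so the data give no direction for this change. A shift beyond the scatter is not expected, and the estimated 1.0-fold higher number from compound 2 to compound 3 (0.01 log units; within the scatter) reflects that. The expected value for compound 3 is 7 mL/min/kg with an estimated range from 3.5 mL/min/kg to 14 mL/min/kg in this assay.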

Compound 3, clearance: 11 mL/min/kg
Beside the measured number, compound 3's estimate is 1.6-fold (0.20 log units) below it, within the range that was stated.
By their numbers in this assay, from the lowest: compounds 2, 1 and 3 (each within the scatter of the next).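

The group on the oxygen on the aromatic ring now has its first measured step: in this assay, cyclobutyl in place of isopropyl gives a 1.6-fold higher number from compound 2 to compound 3 (0.21 log units; within the scatter) and so stays within the scatter. At this position, the added carbon and the four-membered ring therefore leave the number without a distinct shift, though this is shown only with the 2,3-dimethoxypyridin-4-yl group in place. Nothing measured here bears on the reason for this result.

Still open, from the compounds shown here alone, is whether a different group on this oxygen, such as a longer chain or a chain ending in an amine, would move the number in this assay beyond the scatter. Also open, going by these compounds, is whether the same change reads alike with the 2-fluoro-3-methoxyphenyl group of compound 1 in place.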